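The compounds below may be only part of what the source reports. "The series", "measured", "known", "first", "only" and "open" are said of these compounds alone.

In an ADME assay on microsomes from liver (Homo sapiens) for metabolic stability, read by LC-MS, with a stated time of 30 min, tested at 1 uM (on this read-out lower numbers stand for a less stable compound and higher numbers for a more stable compound), three compounds have been measured so far. Compound 1 `Cn1c(C(=O)NCc2ccc(S(=O)(=O)c3ccccc3)cc2)cc2cnccc21` gives 78%, compound 2 `O=C(NCc1ccc(S(=O)(=O)N2CCCCC2)cc1)c1cc2cnccc2s1` gives 15%, and compound 3 `Cc1cccc(S(=O)(=O)c2ccc(CNC(=O)c3cc4cnccc4[nH]3)cc2)c1` gives 49%. Compound 2 stands lowest of the three: its nearest neighbour is compound 3, a number that lies beyond the usual scatter, and compound 1 lies further still.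

The step to compound 4 `O=C(NCc1ccc(S(=O)(=O)N2CCCCC2)cc1)c1cc2ccncc2[nH]1` changes the bicyclic group attached to the carbonyl carbon of compound 2: a group of 9 heavy atoms (7 carbon, 2 nitrogen; one five-membered aromatic ring with 1 hetero atom, one six-membered aromatic ring with 1 hetero atom) in place of a group of 9 heavy atoms (7 carbon, 1 nitrogen, 1 sulfur; one five-membered aromatic ring with 1 hetero atom, one six-membered aromatic ring with 1 hetero atom), on a carbonyl carbon. For the measured compounds named here, no measured pair differs in exactly this way, so the direction of the step has to be judged from the compounds at hand.

Compound 3, which also carries on its carbonyl carbon a bicyclic group with one hydrogen-bond donor, gives 49%, a good deal higher than compound 2, so a rise beyond the scatter is expected, though the rest of compound 4 matches compound 2, not compound 3. The step expected in this assay is a number 20 percentage points higher from compound 2 to compound 4 (beyond the scatter). Compound 4 is therefore estimated at 35%, within a range from 15% to 60%.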

Compound 4, percent of the compound remaining: 50%
The estimate for compound 4 lay 15 percentage points below the measured number; low and high end bracket the measured number.
By their numbers in this assay, from the lowest: compound 2; then compounds 3 and 4 (each within the scatter of the next); then compound 1.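

The result in this assay is a number 35 percentage points higher from compound 2 to compound 4 (beyond the scatter) when only the bicyclic group on the carbonyl carbon changes, so this position alone can move the number by a large amount while the rest of the molecule stays fixed. The two groups have the same size, but the entering group has nitrogen in place of sulfur and carries a hydrogen-bond donor that the leaving group lacks, and this single pair cannot show which difference matters. Nothing measured here explains the step.

On these data alone, it remains open whether the same change would give a similar step with a different group on the rest of the molecule. Also open, as far as these compounds go, is how a bicyclic group containing oxygen in place of that sulfur or nitrogen would compare on the same carbonyl carbon.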